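The source may hold more compounds than are shown below. What is called first, only, known or untested is meant among the compounds shown, and "the series" means these compounds.

Of the compounds shown here, two have so far been measured in a functional assay on RAW264.7 cells (Mus musculus) for inhibition, with a stated time of 4 days; a higher number here means a weaker inhibitor, a lower number a stronger inhibitor. Compound 1, `COc1ccc(/C=C/C(=O)c2cccc(N=[N+]=[N-])c2)cc1O`, gives 1960 nM in this assay. For the measured compounds named here, compound 2, `COc1cc(/C=C/C(=O)c2cccc(-n3cc(-c4ccccc4)nn3)c2)ccc1O`, gives 16800 nM in this assay, the higher of the two numbers; its only neighbour is compound 1, whose number is lower by a gap that lies beyond the usual scatter, so compound 2 is the weaker inhibitor of the pair. Compound 3, `CCCCCc1ccc(-c2cn(-c3cccc(C(=O)/C=C/c4ccc(O)c(OC)c4)c3)nn2)cc1`, has not yet been measured. It differs from compound 2 in one place: pentyl in place of hydrogen on an aromatic carbon. The change puts a pentyl chain on an aromatic carbon of a six-membered aromatic ring of carbon only; read one bond further out, a phenyl becomes a 4-pentylphenyl. Going by the values given here, no measured pair shows what such a change does in this assay, so there is no step to lean on. The expected step is small, a 1.4-fold lower number from compound 2 to compound 3 (0.15 log units; within the scatter), likely no larger than the scatter, with the direction left open. Compound 3 is estimated at 12000 nM, with a range from 4000 nM to 40000 nM.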

Compound 3, half-maximal inhibitory concentration: 5780 nM
Compound 3: middle estimate off by 2.1-fold (0.32 log units), on the high side; low and high end bracket the measured number.
By their numbers in this assay, from the lowest: compound 1; then compound 3; then compound 2.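

In this assay, turning a phenyl into a 4-pentylphenyl brings a 2.9-fold lower number from compound 2 to compound 3 (0.46 log units; beyond the scatter) and so a modestly stronger inhibitor. For the compounds shown here, this is the first measured step at this position, and it shows that an aromatic carbon para to a large group can carry a pentyl chain without any loss of inhibition; the larger molecule is in fact the better inhibitor of this pair. Going by these compounds alone, the data show only that the number falls, and nothing available here bears on why it does so.

One step cannot show whether the gain depends on the length of the chain, so a methyl group, a propyl group or a longer chain such as octyl could each give a smaller, similar or larger step. Going by these compounds, it also remains open whether a pentyl chain would do the same on another carbon of that ring, and whether a chain ending in an amine or a carboxylic acid would be accepted at this position.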